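The compounds below may be only part of what the source reports. "The series", "measured", "known", "first", "only" and "open" are said of these compounds alone.

Measured so far in a functional assay on the whole organism (strain Wistar) for inhibition, with Rattus norvegicus as the target, read by paw edema, with stated times of 1 h and 2 h, at a dose of 10 mg/kg by the intraperitoneal route; on this read-out lower numbers stand for less inhibition and higher numbers for more inhibition at the one dose given (going by the name of the read-out):
Compound 1 `COc1cc(/C=C/C(=O)/C=C(O)/C=C/c2ccc(OC(=O)[C@H](CC(C)C)NC(=O)OCc3ccccc3)c(OC)c2)ccc1OC(=O)[C@H](CC(C)C)NC(=O)OCc1ccccc1` gives 10%.
Compound 2 `COc1cc(/C=C/C(=O)/C=C(O)/C=C/c2ccc(OC(=O)[C@H](C)NC(=O)OC(C)(C)C)c(OC)c2)ccc1OC(=O)[C@H](C)NC(=O)OC(C)(C)C` gives 11%.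

In this assay compound 2 holds the highest of the two numbers, yet the number for compound 1 lies only slightly lower and within the scatter, so the two values show no real separation. Compound 3 `COc1cc(/C=C/C(=O)/C=C(O)/C=C/c2ccc(OC(=O)[C@@H](C)NC(=O)OC(C)(C)C)c(OC)c2)ccc1OC(=O)[C@@H](C)NC(=O)OC(C)(C)C` is not yet measured. Its relation to compound 2 is this: the two compounds have the same atoms and bonds and differ only in configuration as drawn: 2 of 5 stereo elements differ; a stereocentre at a saturated chain carbon is drawn S in compound 2 and R in compound 3; a stereocentre at a saturated chain carbon is drawn S in compound 2 and R in compound 3. Within the data shown here, no step between measured compounds is available to show what such a change does here. Compound 1 at 10% and compound 2 at 11% sit close together despite differing in several places, so a change that touches only the drawn configuration is expected to give no step beyond the scatter in this assay. The expected step is no change at the digits printed from compound 2 to compound 3 (within the scatter). Compound 3 is therefore estimated at 11%, with a range from 2% to 20%.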

Compound 3, a percentage reported as inhibition, in the whole organism at one dose (the size of the read-out at that dose, not a potency): 29%
For compound 3 the middle estimate is 18 percentage points below the measured one; measured number above the stated range.
By their numbers in this assay, from the lowest: compounds 1 and 2 (each within the scatter of the next); then compound 3.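

In this assay, switching both saturated chain stereocentres from S to R gives a number 18 percentage points higher from compound 2 to compound 3 (beyond the scatter). Compound 1 and compound 2 differ in several places at once, so they could not show whether configuration at these centres matters in this read-out, whereas this pair shows that it does. The step can be assigned to configuration alone, because the atoms and bonds stay the same, as recorded here: the fact that compounds 2 and 3 differ only in the configuration as drawn.

Going by these compounds, both centres change together here, so it remains open what changing just one would do and whether the same switch would raise the number for compound 1. On these data alone, it is also open whether the R configuration would give a similar result with a free amine in place of the carbamate on these chains.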